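Cutting the aryl amidine substituent in a naphthoquinone series

The source may report more compounds than this note shows. Statements on the series, on what has been measured and on what is new or still open speak of the compounds shown alone.

The two measured compounds share a naphthoquinone core carrying an aminoethyl-amidine side chain with a tosyl group. Compound 1 `Cc1ccc(S(=O)(=O)/N=C(/CCNC2=CC(=O)c3ccccc3C2=O)Nc2cccc(C(F)(F)F)c2)cc1` gives 78500 nM in a functional assay on A549 cells (Homo sapiens) for cytotoxicity, read by MTT assay, with a stated time of 48 h (a higher number here means a weaker inhibitor, a lower number a stronger inhibitor), which is the higher of the two numbers recorded; its neighbour compound 2 `COc1ccc(N/C(CCNC2=C(Br)C(=O)c3ccccc3C2=O)=N\S(=O)(=O)c2ccc(C)cc2)cc1OC` gives 17500 nM in this assay, a gap that lies beyond the scatter. Compound 3 `Cc1ccc(S(=O)(=O)/N=C(\N)CCNC2=CC(=O)c3ccccc3C2=O)cc1` has not been measured. It differs from compound 1 in one place: hydrogen in place of 3-(trifluoromethyl)phenyl on an amine nitrogen. Among the measured compounds shown here, no step between two measured compounds isolates this change, so nothing on record shows its effect. Compound 1 already sits at the weak end of what was measured, and compound 3 is expected to give a number of similar size or somewhat higher, a step of a 1.4-fold higher number from compound 1 to compound 3 (0.15 log units; within the scatter) that may not reach beyond the scatter. Compound 3 is therefore estimated at 110000 nM, within a range of 40000 nM to 300000 nM.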

Compound 3, half-maximal inhibitory concentration: 26600 nM
Compound 3: middle estimate off by 4.1-fold (0.62 log units), on the high side; the measured number lies below the stated range.
By their numbers in this assay, from the lowest: compounds 2 and 3 (each within the scatter of the next); then compound 1.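

Among the compounds shown here, replacing the 3-(trifluoromethyl)phenyl group on this amine nitrogen with hydrogen gives a 3.0-fold lower number from compound 1 to compound 3 (0.47 log units; beyond the scatter) in this assay, the first measured step at this position. In this pair the aryl group is therefore not needed to reach the lower number, and the simple amino form does better, though the step is modest. No measurement on record bears on why the number falls.

The step removes the phenyl ring and its trifluoromethyl group together, so the compounds shown cannot separate the two, and an unsubstituted phenyl group on this nitrogen would be the direct test. They also leave open how a methyl group or a longer alkyl chain would compare here, and whether the step would carry over to the core of compound 2.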